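The compounds below may be only part of what the source reports. "The series", "measured", "known", "first", "only" and "open" are said of these compounds alone.

Of the compounds shown here, two that share one core have been tested in a functional assay on WI-38 VA13 cells (Homo sapiens) for cytotoxicity; on this read-out lower numbers stand for an effect already at smaller amounts and higher numbers for an effect only at larger amounts of compound. Compound 1, with structure `Cc1c(C(=O)c2cccc(OC(C)C)c2)oc2cc(-c3ccccc3)cc(O)c12`, gives 0.35 ug/mL. Compound 2, with structure `Cc1c(C(=O)c2cccc(C(F)(F)F)c2)oc2cc(-c3ccccc3)cc(O)c12`, reaches only a limit of the assay: in this assay compound 2 gives > 4 ug/mL. For the measured compounds named here, the single change between them, trifluoromethyl in place of isopropoxy on an aromatic carbon, brought an at least 11-fold higher number from compound 1 to compound 2 (1.05 log units; beyond the scatter); that figure rests on (the limit of > 4 ug/mL in this assay, at which 1 of the 2 values shown sits), so the true gap could be larger still.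

Compound 3, with structure `Cc1c(C(=O)c2cccc(CN(C)C)c2)oc2cc(-c3ccccc3)cc(O)c12`, has not yet been measured. It differs from compound 2 in one place: (dimethylamino)methyl in place of trifluoromethyl on an aromatic carbon. Going by the values given here, no measured step swaps trifluoromethyl for another group, so the only step that touches this position, an at least 11-fold higher number from compound 1 to compound 2 (1.05 log units; beyond the scatter), shows merely that a change here can move the read-out strongly. Going by these compounds, since compound 2 stands at a limit, its own number is unknown, and any expectation for compound 3 is loose. Compound 3 is estimated at 2 ug/mL, within a range of 0.5 ug/mL to 8 ug/mL, which means an expected step of an at least 2.0-fold lower number from compound 2 to compound 3 (0.30 log units; that floor lies within the scatter), with a fair chance that this assay again reports only a limit.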

Compound 3, half-maximal effective concentration: 0.09 ug/mL
The estimate for compound 3 lay 22-fold (1.35 log units) above the measured number, outside the stated range (below it).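

Replacing trifluoromethyl with (dimethylamino)methyl gives an at least 44-fold lower number from compound 2 to compound 3 (1.64 log units; beyond the scatter), so in this assay this position can also drive the number down and not only up, and a group containing nitrogen is enough to do this. Going by these compounds, the true size of that step is unknown, since the value for compound 2 is a limit and not a number: the limit of > 4 ug/mL in this assay, at which 1 of the 3 values shown sits A firmer comparison, with real numbers on both sides, is the change from isopropoxy to (dimethylamino)methyl, which gives a 3.9-fold lower number from compound 1 to compound 3 (0.59 log units; beyond the scatter), a modest step that leaves compound 3 with the lowest number of the three.

On these data alone, with only these three groups at this position, it remains open whether the low number goes with the nitrogen itself or with the whole (dimethylamino)methyl group. A primary amine, a dimethylamino group on a longer chain, or a carboxylic acid at the same place would help to separate these possibilities, and would show whether the trend holds beyond these three compounds.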